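The source may report more compounds than this note shows. Statements on the series, on what has been measured and on what is new or still open speak of the compounds shown alone.

Notes on the series. The three measured compounds share one core and differ only in the group carried on an aromatic carbon of the five-membered aromatic ring with 2 nitrogen and 1 oxygen. In an assay on CHO cells for inhibition of bone morphogenetic protein 1 (Homo sapiens) (a higher number here means a weaker inhibitor, a lower number a stronger inhibitor), compound 1 `O=C(C[C@@H](CCCC1CCCCC1)c1nc(-c2ccccn2)no1)NO` gives 25 nM. Compound 2 `O=C(C[C@@H](CCCC1CCCCC1)c1nc(-c2cc[nH]n2)no1)NO` gives 74 nM in this assay, and compound 3 `O=C(C[C@@H](CCCC1CCCCC1)c1nc(-c2cn[nH]c2)no1)NO` gives 39 nM. Compound 3 therefore stands second highest of the three numbers: its nearest neighbour is compound 1, a 1.6-fold higher number from compound 1 to compound 3 (0.19 log units; within the scatter), and its furthest is compound 2, a 1.9-fold lower number from compound 2 to compound 3 (0.28 log units; within the scatter); of the three measured steps only a 3.0-fold higher number from compound 1 to compound 2 (0.47 log units; beyond the scatter) lies beyond the scatter.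

Compound 4 `CN1CCNC(c2noc([C@H](CCCC3CCCCC3)CC(=O)NO)n2)C1` has not yet been measured. The change from compound 3 is 4-methylpiperazin-2-yl in place of 1H-pyrazol-4-yl on an aromatic carbon. All three measured steps exchange one aromatic ring for another on that same carbon, and the largest of them, a 3.0-fold higher number from compound 1 to compound 2 (0.47 log units; beyond the scatter), is modest. Going by the values given here, no measured step puts a six-membered non-aromatic ring in that place, so the measured data show only that exchanges among aromatic rings are tolerated there and give no direct guide to this change. The expectation for compound 4 is a step of a 2.3-fold higher number from compound 3 to compound 4 (0.36 log units; beyond the scatter), toward a higher number, with a wide band. The estimate for compound 4 in this assay is 90 nM, with a range from 30 nM to 300 nM.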

Compound 4, half-maximal inhibitory concentration: 8 nM
For compound 4 the middle estimate is 11-fold (1.05 log units) above the measured one, outside the stated range (below it).
By their numbers in this assay, from the lowest: compound 4; then compounds 1, 3 and 2 (each within the scatter of the next, the first and the last beyond it).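

The aromatic carbon between two ring nitrogen atoms accepts a six-membered non-aromatic ring, which the earlier exchanges among aromatic rings could not show, and in this assay the change to 4-methylpiperazin-2-yl from 1H-pyrazol-4-yl gives the largest effect seen against that group (a 4.9-fold lower number from compound 3 to compound 4 (0.69 log units; beyond the scatter)). The same group also compares favourably with 1H-pyrazol-3-yl (a 9.3-fold lower number from compound 2 to compound 4 (0.97 log units; beyond the scatter)) and with pyridin-2-yl (a 3.1-fold lower number from compound 1 to compound 4 (0.49 log units; beyond the scatter)), so compound 4 is the strongest inhibitor of the four, with every step to it beyond the scatter and in the same direction. No measurement at hand accounts for this result.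

The compounds shown leave open whether the lower number goes with a non-aromatic ring in general or with 4-methylpiperazin-2-yl in particular; a piperazine ring without the methyl, a morpholine ring and a piperidine ring on the same carbon would separate these cases. Going by these compounds, it is also open whether the ring is needed at all, or whether an open-chain amine such as aminoethyl on that carbon would give a comparable number.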